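The source may hold more compounds than are shown below. What is called first, only, known or untested is meant among the compounds shown, and "the series" means these compounds.

Compound 1 `COc1ccc2cccc(C3CNC(=O)C3)c2c1` is the weaker of the two compounds measured in an assay (Ovis aries) for binding affinity to melatonin receptor type 1A (Homo sapiens); on this read-out lower numbers stand for stronger inhibition and higher numbers for weaker inhibition: there compound 1 gives 1580 nM. Among the measured compounds shown here, the only other measured compound, compound 2 `CC(=O)NCCCCc1cccc2c1SCCO2`, gives 126 nM in this assay, a difference that lies beyond the usual scatter, so compound 1 stands at the high end of the numbers available. For the measured compounds named here, no step between compounds differing in a single place has been measured, so any expectation for the next compound rests on the two values alone and on the structural change itself.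

Compound 3 `CNC(=O)CCc1cccc2ccc(OC)cc12` has not yet been measured in this assay. It differs from compound 1 in one place: 2-(methylcarbamoyl)ethyl in place of 5-oxopyrrolidin-3-yl on an aromatic carbon. The change keeps the count of heavy atoms, donors and acceptors, but trades the ring for a chain of the same length.

He expects compound 3 to give a lower number than compound 1, because compound 2, the one measured compound without such a ring, gives 126 nM. The step he expects, a 53-fold lower number from compound 1 to compound 3 (1.72 log units; beyond the scatter), should go beyond the scatter. His estimate for compound 3 in this assay is 30 nM, within a range from 3 nM to 300 nM.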

Compound 3, half-maximal inhibitory concentration: 12.6 nM
The estimate for compound 3 lay 2.4-fold (0.38 log units) above the measured number; the range from low to high includes it.
By their numbers in this assay, from the lowest: compound 3; then compound 2; then compound 1.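

In this assay, among the compounds shown here, putting 2-(methylcarbamoyl)ethyl in place of 5-oxopyrrolidin-3-yl on an aromatic carbon gives a 130-fold lower number from compound 1 to compound 3 (2.10 log units; beyond the scatter), the only single-place step available so far and a large one. The two groups have the same counts of heavy atoms, hydrogen-bond donors, hydrogen-bond acceptors and double bonds outside aromatic rings, and the difference in these counts lies only in the five-membered non-aromatic ring, which the entering group lacks, so this position responds strongly to a change that leaves those counts untouched. No available measurement bears on the reason for this step.

The compounds shown leave open how the number would move with a longer chain at this aromatic carbon, such as 3-(methylcarbamoyl)propyl, or with a different group at the end of the chain, such as 2-(ethylcarbamoyl)ethyl. They also leave open whether 2-acetamidoethyl, with the amide turned around, would follow compound 3, and whether a six-membered lactam ring at the same carbon would follow compound 1.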